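A few compounds are considered here, and "the series" means these few. Any claim that something is new, unique, unknown or untested is made for them only; others in the source may bear on it.

Measured so far: compound 1 `Cn1cncc1CN1CC(N(CCn2cccc2)S(=O)(=O)c2ccccn2)Cc2cc(C#N)ccc21` gives 12.4 10^-6 cm/s; compound 2 `Cn1cncc1CN1CC(N(CC2CCN(C(=O)N3CCCCC3)CC2)S(=O)(=O)c2ccccn2)Cc2cc(C#N)ccc21` gives 0.6 10^-6 cm/s.

In an ADME assay on Caco-2 cells (Homo sapiens) for permeability, in the apical to basolateral direction (a higher number here means that the compound crosses the layer faster, a lower number that the compound crosses the layer more slowly), compound 1 holds the higher of the two numbers, with compound 2 lying well beyond the scatter below it. Compound 3 `CCOC(=O)N1CCC(CN(C2Cc3cc(C#N)ccc3N(Cc3cncn3C)C2)S(=O)(=O)c2ccccn2)CC1` is not yet measured; it differs from compound 1 by 1-(ethoxycarbonyl)piperidin-4-yl in place of (1H-pyrrol-1-yl)methyl on a saturated chain carbon bound to a sulfonamide nitrogen. Among the compounds with values here, no measured pair shows this change, so the expectation rests on the two values. A drop beyond the scatter is expected, from compound 1 to compound 3 of a 5.0-fold lower number from compound 1 to compound 3 (0.70 log units; beyond the scatter), smaller than the gap to compound 2 because compound 2 gives 0.6 10^-6 cm/s with a larger appended chain. For compound 3 the estimate is 2.5 10^-6 cm/s, between 0.8 10^-6 cm/s and 7 10^-6 cm/s.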

Compound 3, apparent permeability: 2.6 10^-6 cm/s
Estimate against measurement, compound 3: 1.0-fold (0.02 log units) below; the range from low to high includes it.
By their numbers in this assay, from the lowest: compound 2; then compound 3; then compound 1.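

In this assay, within the data shown here, 1-(ethoxycarbonyl)piperidin-4-yl in place of (1H-pyrrol-1-yl)methyl on a saturated chain carbon bound to a sulfonamide nitrogen gives a 4.8-fold lower number from compound 1 to compound 3 (0.68 log units; beyond the scatter) as the first single-change reading at this position. Ethoxy in place of piperidin-1-yl on a carbonyl carbon gives a 4.3-fold higher number from compound 2 to compound 3 (0.64 log units; beyond the scatter), so the group on the carbonyl alone moves the number beyond the scatter. The data offer no explanation for either step.

Open, from the compounds shown here alone, is how a smaller methyl group on that carbonyl would read. Also open, going by these compounds, is how a piperidine carrying a free amine, without the carbonyl, would compare.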